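Nitro in Place of Methoxy: Expecting Compound 4

The source may report more compounds than this note shows. Statements on the series, on what has been measured and on what is new or still open speak of the compounds shown alone.

Compound 1 `COc1ccc(/C=C/C(=O)c2c(O)cc(O)cc2OC)cc1` gives > 50000 nM, a limit of the assay rather than a number.
Compound 2 `COc1cc(O)cc(O)c1C(=O)/C=C/c1ccc([N+](=O)[O-])cc1` gives > 50000 nM, also a limit.
Among the compounds with values here, compound 3 `COc1cc(OC)c(C(=O)/C=C/c2ccccc2OC)c(OC)c1` gives 19800 nM in a functional assay on A549 cells (Homo sapiens) for inhibition, read by MTT assay, with a stated time of 72 h (on this read-out lower numbers stand for stronger inhibition and higher numbers for weaker inhibition), the only number among the three.

From compound 1 to compound 2 the change is nitro in place of methoxy on an aromatic carbon. Its step that the two limits leave unreadable from compound 1 to compound 2 cannot be sized because both values sit at the limit of > 50000 nM in this assay, at which 2 of the 3 values shown sit.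

Compound 4 `COc1cc(OC)c(C(=O)/C=C/c2ccccc2[N+](=O)[O-])c(OC)c1` is not yet measured. It differs from compound 3 by nitro in place of methoxy on an aromatic carbon, the same kind of change, though here ortho to a large group rather than para to a large group. The difference between the core of compound 1 and the core of compound 3 is not broken down here. With no readable guide from the measured pair, the step of a 1.0-fold higher number from compound 3 to compound 4 (0.00 log units; within the scatter) is expected to be small, resting on compound 3 at 19800 nM. Compound 4 is estimated at 20000 nM, between 6000 nM and 50000 nM.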

Compound 4, half-maximal inhibitory concentration: 10700 nM
Compound 4: the middle estimate sits 1.9-fold (0.27 log units) above what was measured, within the range that was stated.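

On the core of compound 3, nitro in place of methoxy on an aromatic carbon gives, in this assay, a 1.9-fold lower number from compound 3 to compound 4 (0.27 log units; within the scatter), so the two compounds cannot be told apart on this read-out. On the core of compound 1 the same change cannot be read, because the values of both compounds there are limits and not numbers: the limit of > 50000 nM in this assay, at which 2 of the 4 values shown sit. Within the data shown here, the change therefore cannot be compared between the two cores, and the one readable step applies only to a group ortho to a large group on the core of compound 3.

The compounds shown leave open how an amine or a carboxylic acid in that same place would read on either core.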